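The compounds below may be only part of what the source reports. "The series", "measured", "known", "first", "only" and "open" are said of these compounds alone.

Measured so far in an assay for binding affinity to dual specificity mitogen-activated protein kinase kinase 4 (Homo sapiens), read by KINOMEscan, tested at 100 nM; a higher number here means a weaker effect of the compound at the concentration tested, a lower number a stronger effect:
- compound 1, `CCCS(=O)(=O)Nc1ccc(F)c(C(=O)c2n[nH]c3ncc(-c4ccccc4C)cc23)c1F`: 7%
- compound 2, `CCCS(=O)(=O)Nc1ccc(F)c(C(=O)c2n[nH]c3ncc(-c4ccccc4O)cc23)c1F`: 9%
- compound 3, `CCCS(=O)(=O)Nc1ccc(F)c(C(=O)c2n[nH]c3ncc(-c4ccc(OC)cc4Cl)cc23)c1F`: 5.3%

Compound 3 carries the lowest of the three numbers, but its steps to both others stay within the scatter: a number 1.7 percentage points lower from compound 1 to compound 3 (within the scatter) and a number 3.7 percentage points lower from compound 2 to compound 3 (within the scatter). The aryl group on the shared core has so far been varied without a step beyond the scatter in this assay; the hydroxy for methyl exchange likewise gave a number 2 percentage points higher from compound 1 to compound 2 (within the scatter).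

Compound 4, `CCCS(=O)(=O)Nc1ccc(F)c(C(=O)c2n[nH]c3ncc(-c4ccc(S(=O)(=O)NCC)cc4)cc23)c1F`, carries 4-(ethylsulfamoyl)phenyl in place of 2-chloro-4-methoxyphenyl on an aromatic carbon. The two steps that bear on it, from compound 1 to compound 3 and from compound 2 to compound 3, both changed the same aryl group and both stayed within the scatter. The present change is larger in what it counts than either, so the measured steps give only weak guidance, yet none of them points in a direction beyond the scatter.

Compound 4 is therefore expected to give 8% in this assay, within 2% to 22%. The expected step from compound 3 is a number 2.7 percentage points higher from compound 3 to compound 4 (within the scatter), no more than the scatter.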

Compound 4, a percentage reported as activity, at one concentration (the size of the read-out at that concentration, not a potency): 3%
Compound 4: middle estimate off by 5 percentage points, on the high side; measured number inside the range.
By their numbers in this assay, from the lowest: compounds 4, 3, 1 and 2 (each within the scatter of the next).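

In this assay, going by these compounds alone, the position para to a fused ring on the shared core also accepts 4-(ethylsulfamoyl)phenyl, the first group whose name carries a sulfamoyl unit and the first change here to bring in a hydrogen-bond donor alongside a nitrogen and a sulfur. All three steps to it stay within the scatter (a number 2.3 percentage points lower from compound 3 to compound 4 (within the scatter)), (a number 6 percentage points lower from compound 2 to compound 4 (within the scatter)) and (a number 4 percentage points lower from compound 1 to compound 4 (within the scatter)), so the aryl groups shown so far, from 2-methylphenyl to this much longer substituent, cannot be told apart at this concentration. Nothing given here offers a cause for this outcome.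

As far as these compounds go, it remains open whether a carboxylic acid, a piperazine or a longer chain on the sulfamoyl nitrogen would move the number beyond the scatter. Also open is whether the aryl groups shown would differ in a full potency measurement.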